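This account rests on a few compounds, and the source may have more. Where it says the series, first, only, none or still open, it means among the compounds named here.

The series shares the core of compound 1, `CCC1C(=O)N(C)c2cnc(-n3ccc4cc(C(N)=O)ccc43)nc2N1c1ccn(C)n1`, which in a functional assay on Huh-7 cells (Homo sapiens) for antiproliferative activity, read by CCK-8 assay, with a stated time of 72 h (on this read-out higher numbers stand for weaker inhibition of growth and lower numbers for stronger inhibition of growth), is reported as "not active" (no number reported), with no number given. Among the compounds with values here, compound 2, `CCCCNC(=O)c1ccc2c(ccn2-c2ncc3c(n2)N(C2CCCC2)[C@H](CC)C(=O)N3C)c1`, carries different groups at more than one place, and in this assay compound 2 gives 683 nM; no single-point step joins these two, so the pair shows only one numberless result and one number. Compound 3, `CCC1C(=O)N(C)c2cnc(-n3ccc4cc(C(=O)NC5CCCC5)ccc43)nc2N1c1ccn(C)n1`, differs from compound 1 by cyclopentyl in place of hydrogen on an amide-type nitrogen. Within the data shown here, no measured step of this kind exists, so the size of the change in this assay cannot be read from a neighbour; a move beyond the scatter toward stronger inhibition is expected, since compound 1 left no number to start from, but its extent is open. Compound 3 is estimated at 2500 nM in this assay, within a range of 500 nM to 15000 nM.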

Compound 3, concentration for 50% growth inhibition: "not active" (no number reported)
No number was reported for compound 3; the estimate stays without a comparison.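

Compound 1 and compound 3 both come back without a number in this assay, so no step can be read between them. No further data bear on this result. From the compounds shown here alone, the effect of cyclopentyl on the amide-type nitrogen on growth inhibition therefore remains open.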